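The compounds below may be only part of what the source reports. "The series", "measured", "known", "first", "only" and "open" are said of these compounds alone.

Measured compounds in an assay on S100 cells for inhibition of Polyunsaturated fatty acid 5-lipoxygenase (Homo sapiens), read by HPLC, with stated times of 15 min and 10 min; a higher number here means a weaker inhibitor, a lower number a stronger inhibitor:

Compound 1 `COc1cccc(-c2nc3ccc(C)cn3c2NC2CCCCC2)c1`: 430 nM
Compound 2 `Oc1ccc(-c2nc3ccc(Br)cn3c2NC2CCCCC2)cc1`: 900 nM
Compound 3 `Cc1ccc2nc(-c3ccc([N+](=O)[O-])cc3)c(NC3CCCCC3)n2c1`: a limit, > 30000 nM

Of the two numbers that were obtained, compound 1 has the lower one, so it is the stronger inhibitor of the two; the value of compound 2 is a little beyond the usual scatter away from it. Compound 3 gave no number at all, only (the limit of > 30000 nM in this assay, at which 1 of the 3 values shown sits). The three measured compounds differ from one another in more than one place at once, so no single structural change can be tied to a measured shift, and the ring bearing the cyclohexylamino group and the aryl group carries a methyl in compound 1 and compound 3 but a bromine in compound 2.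

The next compound, compound 4 `Cc1ccc2nc(-c3ccccc3O)c(NC3CCCCC3)n2c1`, is made from compound 1 by one change: 2-hydroxyphenyl in place of 3-methoxyphenyl on an aromatic carbon. The hydroxyphenyl of compound 2 sat on a different core and gave a somewhat higher number than compound 1, which is the only hint available for a hydroxyl in this part of the molecule. On that thin basis a small weakening, of roughly the size seen between compound 1 and compound 2, is expected, though a value within the scatter of compound 1 would not surprise. The expected step in this assay is a 2.1-fold higher number from compound 1 to compound 4 (0.32 log units; beyond the scatter). Compound 4 is thus estimated at 900 nM, with a range from 250 nM to 4000 nM.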

Compound 4, half-maximal inhibitory concentration: 1800 nM
Compound 4: the middle estimate sits 2.0-fold (0.30 log units) below what was measured; the range from low to high includes it.
By their numbers in this assay, from the lowest: compound 1; then compounds 2 and 4 (each within the scatter of the next). At a limit, above all of these: compound 3.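

In this assay, replacing the 3-methoxyphenyl with a 2-hydroxyphenyl on this aromatic carbon gives a 4.2-fold higher number from compound 1 to compound 4 (0.62 log units; beyond the scatter). Among the compounds shown here, this is the first change that can be read on its own, since compound 1 and compound 4 share the same core and the same cyclohexylamino group, and it shows that this swap weakens inhibition modestly while leaving a measurable value. The swap alters two things at once, the kind of oxygen group and its place on the phenyl ring, and nothing measured here explains the step or shows which of the two matters more.

Going by these compounds, what a 3-hydroxyphenyl or a 2-methoxyphenyl would give on this same core remains open, and that pair is what could separate the effect of the group from the effect of its place on the ring. On these data alone, it is also open how this position would respond to a phenyl ring carrying an amine or a carboxylic acid, or to a longer chain ending in a methoxy group.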